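Aryl urea swap in a cytotoxicity-silent series

This account rests on a few compounds, and the source may have more. Where it says the series, first, only, none or still open, it means among the compounds named here.

Three measured members share one core and a diaryl urea. In a functional assay on RPMI-8226 cells (Homo sapiens) for inhibition, read by sulforhodamine B assay, with a stated time of 48 h (on this read-out lower numbers stand for higher toxicity in this test and higher numbers for lower toxicity in this test), compound 1 `COc1cc(-c2nn(-c3cccc(NC(=O)Nc4ccc(Cl)c(Cl)c4)c3)cc2-c2ccncc2)ccc1Cl` reaches only a limit of the assay, > 50000 nM. Compound 2 `O=C(Nc1cccc(-n2cc(-c3ccncc3)c(-c3ccc(Cl)c(O)c3)n2)c1)Nc1ccc(Cl)c(Cl)c1` likewise gives only a limit, > 32500 nM. Compound 3 `COc1cc(-c2nn(-c3cccc(NC(=O)Nc4cccc(C(F)(F)F)c4)c3)cc2-c2ccncc2)ccc1Cl` also stops at a limit, > 50000 nM. Compound 2 therefore stands at the limit of > 32500 nM in this assay, at which 1 of the 3 values shown sits, whereas the other two sit at the limit of > 50000 nM in this assay, at which 2 of the 3 values shown sit; no true number exists for any of them. The two single-point steps, a step that the two limits leave unreadable from compound 1 to compound 2 and a step that the two limits leave unreadable from compound 1 to compound 3, consequently cannot be sized in either direction.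

Compound 4 `O=C(Nc1cccc(-n2cc(-c3ccncc3)c(-c3ccc(Cl)c(O)c3)n2)c1)Nc1ccc(Cl)c(C(F)(F)F)c1` is the next candidate; against compound 2 the change is trifluoromethyl in place of chloro on an aromatic carbon. Of the measured steps only the urea-aryl exchange from compound 1 to compound 3 bears on this change, and it is unreadable, so no size or direction can be carried over. The expectation is that compound 4 again yields nothing beyond the scatter, most likely another limit. Compound 4 is estimated at 50000 nM, with a range from 20000 nM to 120000 nM. The expected step is a step that the limit leaves unreadable from compound 2 to compound 4, judged to lie within the scatter.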

Compound 4, concentration lethal to 50% of the cells: > 32500 nM
Compound 4 was reported as a limit; the forecaster's own chance of this, stated with the estimate: 85%; the middle value lies beyond the limit too.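

In this assay, going by these compounds alone, compound 2 and compound 4 both stop at a limit, so no step between them can be read: the limit of > 32500 nM in this assay, at which 2 of the 4 values shown sit.

Still open is whether trifluoromethyl in place of chloro changes this read-out at all, and at what concentration any compound shown would reach a true value.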